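This account rests on a few compounds, and the source may have more. Where it says the series, first, only, none or still open, it means among the compounds named here.

Working notes on the vinyl sulfone series.

Compound 1 `COc1ccc(CS(=O)(=O)/C=C/c2ccc(F)cc2)cc1` is the reference. In a functional assay on DU-145 cells (Homo sapiens) for antiproliferative activity, read by trypan blue exclusion (a higher number here means a weaker inhibitor, a lower number a stronger inhibitor), compound 1 gives 1250 nM. Compound 2 `COc1ccc(CS(=O)(=O)/C=C/c2ccc(F)cc2OC)cc1` carries one added group on the same core; the change is methoxy in place of hydrogen on an aromatic carbon. That change gives an 8.0-fold higher number from compound 1 to compound 2 (0.90 log units; beyond the scatter), and in this assay compound 2 gives 10000 nM.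

Compound 3 `COc1ccc(CS(=O)(=O)/C=C/c2cc(OC)cc(OC)c2)cc1` has a different core; the difference between the core of compound 3 and the core of compound 1 is not broken down here. In this assay compound 3 reaches only a limit, > 20000 nM, which is the limit of > 20000 nM in this assay, at which 1 of the 3 values shown sits; no number is known for it.

Compound 4 `COc1ccc(CS(=O)(=O)/C=C/c2cc(OC)c(OC)c(OC)c2)cc1` is not yet measured. It differs from compound 3 by methoxy in place of hydrogen on an aromatic carbon. Going by the values given here, this is the same kind of change as the one from compound 1 to compound 2, but the surroundings differ: in compound 2 the entering methoxy sits ortho to a large group and meta to a fluoro group, whereas in compound 4 it sits ortho to two methoxy groups and para to a large group.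

Among the compounds with values here, the only measured instance of a methoxy entering in place of hydrogen, an 8.0-fold higher number from compound 1 to compound 2 (0.90 log units; beyond the scatter), went toward a weaker inhibitor. From compound 3, which already stands at the limit, a step that the limit leaves unreadable from compound 3 to compound 4 is expected for compound 4, with the sign taken from that measured step. For compound 4 the estimate in this assay is 40000 nM, expected between 15000 nM and 150000 nM, and most likely again reported only as a limit.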

Compound 4, half-maximal inhibitory concentration: > 20000 nM
Compound 4: only a limit was reported (the forecaster's own chance of this, stated with the estimate: 80%); the middle value does not contradict the limit.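

No step from compound 3 to compound 4 can be read, because both compounds stand at the same limit in this assay: the limit of > 20000 nM in this assay, at which 2 of the 4 values shown sit.

The compounds shown leave open whether methoxy in place of hydrogen on an aromatic carbon of compound 3 shifts the antiproliferative read-out at all, and in which direction, as it did in the step from compound 1 to compound 2.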